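This account rests on a few compounds, and the source may have more. Where it says the series, first, only, none or still open, it means among the compounds named here.

Measured so far in a functional assay on Jurkat cells (Homo sapiens); on this read-out higher numbers stand for weaker inhibition and lower numbers for stronger inhibition:
- compound 1 `CC(C)[C@H](NC(=O)COc1cccc2ccccc12)C(=O)N[C@@H](CC(=O)O)C(=O)COc1ccc(-c2ccccc2)cc1`: 87900 nM
- compound 2 `CC(C)[C@H](NC(=O)COc1cccc2ccccc12)C(=O)N[C@@H](CC(=O)O)C(=O)COc1ccc(F)c(F)c1`: > 100000 nM (a limit of the assay, not a number)
- compound 3 `CC(C)[C@H](NC(=O)COc1cccc2ccccc12)C(=O)N[C@@H](CC(=O)O)C(=O)COc1cc(F)cc(F)c1`: > 100000 nM (a limit of the assay, not a number)

Compound 3 has no number on this read-out, only a limit, and compound 2 carries the one further limit. The series therefore stands largely at the limit of > 100000 nM in this assay, at which 2 of the 3 values shown sit.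

The next change gives compound 4 `CC(C)[C@H](NC(=O)COc1cccc2ccccc12)C(=O)N[C@@H](CC(=O)O)C(=O)COc1c(Cl)cccc1Cl`, with 2,6-dichlorophenyl in place of 3,5-difluorophenyl on an oxygen on a saturated carbon.

Going by the values given here, three measured steps bear on it. Exchanging 4-phenylphenyl for 3,5-difluorophenyl gave an at least 1.1-fold higher number from compound 1 to compound 3 (0.05 log units; that floor lies within the scatter). Exchanging it for 3,4-difluorophenyl gave an at least 1.1-fold higher number from compound 1 to compound 2 (0.05 log units; that floor lies within the scatter). Moving between the two difluorophenyl groups gave a step that the two limits leave unreadable from compound 2 to compound 3. Among the compounds with values here, none of these gives a readable size, and 2,6-dichlorophenyl has no measured precedent.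

From the compounds shown here alone, no step beyond the scatter is therefore expected in this assay, and the direction stays open, although a second reading at the limit would be no surprise. Within the data shown here, the only number remains that of compound 1, at 87900 nM, and it anchors the expectation. The expected step is an at least 1.4-fold lower number from compound 3 to compound 4 (0.15 log units; that floor lies within the scatter). Compound 4 is estimated at 70000 nM, with an expected range of 10000 nM to 200000 nM.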

Compound 4, half-maximal inhibitory concentration: 3000 nM
Compound 4: the middle estimate sits 23-fold (1.37 log units) above what was measured, outside the stated range (below it).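

In this assay, going by these compounds alone, the group on the oxygen on a saturated carbon can move the read-out by a large step, which the earlier compounds could not show: 2,6-dichlorophenyl gives a clear result in place of 3,5-difluorophenyl (an at least 33-fold lower number from compound 3 to compound 4 (1.52 log units; beyond the scatter)) and in place of 3,4-difluorophenyl (an at least 33-fold lower number from compound 2 to compound 4 (1.52 log units; beyond the scatter)). Within the data shown here, it also stands clear of the only earlier number, with 2,6-dichlorophenyl in place of 4-phenylphenyl (a 29-fold lower number from compound 1 to compound 4 (1.47 log units; beyond the scatter)), so the shared core can reach a far lower number than the earlier compounds gave. Compound 2 and compound 3 still carry limits of the assay, not numbers: the limit of > 100000 nM in this assay, at which 2 of the 4 values shown sit.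

The compounds shown do not separate the effect of the chlorine atoms from that of their placement in 2,6-dichlorophenyl, and a group on the same oxygen that changes only one of the two would bear on that question. From the compounds shown here alone, whether 2,6-dichlorophenyl gives a similarly low number with other groups elsewhere on the shared core also stays open.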